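A few compounds are considered here, and "the series" means these few. Any claim that something is new, unique, unknown or untested is made for them only; others in the source may bear on it.

Of the compounds shown here, two have been measured so far in a functional assay on the whole organism (strain Wistar albino) for inhibition, with Rattus norvegicus as the target, read by paw edema, with stated times of 30 min and 1.5 h, at a dose of 20 mg/kg by the oral route; on this read-out lower numbers stand for less inhibition and higher numbers for more inhibition at the one dose given (going by the name of the read-out). Compound 1 `CC(C)Cc1ccc(C(C)C2=NNC(S)N2N)cc1` gives 46% there, and compound 2 `CC(C)Cc1ccc(C(C)c2nnc(S)n2/N=C/c2ccc(Cl)cc2)cc1` gives 52%. These two numbers lie within the usual scatter of each other, so nothing separates compound 1 from compound 2 on this read-out. Compound 3 `CC(C)Cc1ccc(C(C)c2nnc(S)n2/N=C/c2ccc(Br)cc2)cc1` has not yet been measured. It differs from compound 2 by bromo in place of chloro on an aromatic carbon. Among the measured compounds shown here, no measured pair shows this change, so no step beyond the scatter is expected in this assay in either direction. The estimated step is no change at the digits printed from compound 2 to compound 3 (within the scatter). For compound 3 an inhibition of 52% is expected, within a range from 40% to 64%.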

Compound 3, a percentage reported as inhibition, in the whole organism at one dose (the size of the read-out at that dose, not a potency): 65%
Compound 3: the middle estimate sits 13 percentage points below what was measured; the whole stated range lies below it.
By their numbers in this assay, from the lowest: compounds 1 and 2 (each within the scatter of the next); then compound 3.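

In this assay bromo in place of chloro gives a number 13 percentage points higher from compound 2 to compound 3 (beyond the scatter) and so shows that the read-out responds to the group on this aromatic carbon, para to a large group. The earlier compounds shown here showed no difference beyond the scatter, and none of them varied this position. Nothing shown here accounts for the step.

On these data alone, whether the rise is specific to bromo or extends to iodo remains open. As far as these compounds go, it is also open how a methoxy, a nitro or an amino group would behave at this same place.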